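The compounds below may be only part of what the source reports. "The series", "measured", "known", "first", "only" and "open" are said of these compounds alone.

Compound 1 `C=C1C(=O)O[C@]2(C)CC[C@@H]1C[C@H](O)[C@@]1(C)CC[C@H](O1)C(=C)CC[C@H]2OC(C)=O` opens the set. In a functional assay on HEp-2 cells (Homo sapiens) for cytotoxicity (on this read-out higher numbers stand for weaker inhibition and lower numbers for stronger inhibition), compound 1 gives only a limit, > 20 ug/mL. Compound 2 `C=C1C(=O)O[C@]2(C)CC[C@@H]1C[C@H](OC(C)=O)[C@@]1(C)CC[C@H](O1)C(=C)CC[C@H]2OC(C)=O` carries acetyl in place of hydrogen on an oxygen on a saturated carbon. In this assay compound 2 likewise gives only a limit, > 20 ug/mL. The step that the two limits leave unreadable from compound 1 to compound 2 is accordingly of unknown size. Compound 3 `C=C1C(=O)O[C@]2(C)CC[C@@H]1C[C@H](O)[C@@]1(C)CC[C@H](O1)[C@](C)(O)CCC2=O` rests on another core; the difference between the two cores is not broken down here. In this assay compound 3 again gives only a limit, > 20 ug/mL. All three measured values sit at one point, (the limit of > 20 ug/mL in this assay, at which 3 of the 3 values shown sit). Compound 4 `C=C1C(=O)O[C@]2(C)CC[C@@H]1C[C@H](OC(C)=O)[C@@]1(C)CC[C@H](O1)[C@](C)(O)CCC2=O` carries acetyl in place of hydrogen on an oxygen on a saturated carbon, the same change as that from compound 1 to compound 2, at the same place. The step that the limit leaves unreadable from compound 3 to compound 4 is expected to be small, resting on the unreadable step that the two limits leave unreadable from compound 1 to compound 2 and on (the limit of > 20 ug/mL in this assay, at which 3 of the 3 values shown sit). Compound 4 is therefore estimated at 40 ug/mL, most likely returned as a limit again.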

Compound 4, half-maximal inhibitory concentration: > 20 ug/mL
Compound 4: no number, only a limit; the forecaster's own chance of this, stated with the estimate: 85%; the middle value lies beyond the limit too.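

In this assay compound 4 gives > 20 ug/mL, a limit, so the step from compound 3 to compound 4 cannot be read. The compounds shown leave open how far acetyl in place of hydrogen, or the difference between the two cores, shifts the read-out: the limit of > 20 ug/mL in this assay, at which 4 of the 4 values shown sit.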